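Dropping the Trifluoromethyl Group: What to Expect

A few compounds are considered here, and "the series" means these few. Any claim that something is new, unique, unknown or untested is made for them only; others in the source may bear on it.

Compound 1, `COc1ccn2c(-c3ccc(NC(=O)c4ccc([N+](=O)[O-])o4)cc3)cnc2c1`: 860 nM
Compound 2, `COc1ccn2c(-c3ccc(NC(=O)c4ccc([N+](=O)[O-])o4)c(C)c3C(F)(F)F)cnc2c1`: 2720 nM

In a functional assay on MGC-803 cells (Homo sapiens) for antiproliferative activity, read by CCK-8 assay, with a stated time of 72 h (a lower number here means a stronger inhibitor, a higher number a weaker inhibitor), compound 2 gives the highest of the two numbers, and compound 1 gives the nearer one, a step beyond the usual scatter. Compound 3, `COc1ccn2c(-c3ccc(NC(=O)c4ccc([N+](=O)[O-])o4)c(C)c3)cnc2c1`, differs from compound 2 by hydrogen in place of trifluoromethyl on an aromatic carbon. For the measured compounds named here, no measured pair shows this exact change, but compound 3 lies between compound 1 and compound 2 in structure, so the step of a 2.1-fold lower number from compound 2 to compound 3 (0.32 log units; beyond the scatter) is expected to fall toward a lower number, beyond the scatter. For compound 3 the estimate is 1300 nM, within 550 nM to 3100 nM.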

Compound 3, half-maximal inhibitory concentration: 1380 nM
Compound 3: middle estimate off by 1.1-fold (0.03 log units), on the low side; measured number inside the range.
By their numbers in this assay, from the lowest: compounds 1, 3 and 2 (each within the scatter of the next, the first and the last beyond it).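

Taken alone, hydrogen in place of trifluoromethyl gives a 2.0-fold lower number from compound 2 to compound 3 (0.29 log units; within the scatter) in this assay, so this single swap cannot be told apart from the variation between repeat measurements. Methyl in place of hydrogen, also a single change, gives a 1.6-fold higher number from compound 1 to compound 3 (0.21 log units; within the scatter), and it cannot be told apart either. Nothing measured here offers an explanation for these steps. From the compounds shown here alone, whether an amine, a carboxylic acid or a nitrile on this aromatic carbon would move the number beyond the scatter stays open. So does the effect of a longer chain in place of the methyl group.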